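Nitro in place of chloro: expected tolerance of compound 4

A few compounds are considered here, and "the series" means these few. Any claim that something is new, unique, unknown or untested is made for them only; others in the source may bear on it.

Measured in an ADME assay on MDBK cells (Bos taurus) for cytotoxicity, read by MTT assay, with a stated time of 96 h; a lower number here means that less compound is tolerated, a higher number that more compound is tolerated:
- compound 1 `Clc1cccc(/N=N/N2CCCC2)c1`: > 100000 nM (a limit, not a number)
- compound 2 `Fc1ccc(F)c(/N=N/c2ccc(NC[C@@H]3CCCN4CCCC[C@H]34)c3c2CCCC3)c1`: 64000 nM
- compound 3 `COc1ccc(/N=N/N2CCCC2)cc1`: 60000 nM

In this assay compound 1 gives > 100000 nM, which is a limit of the assay and not a number. Compound 1 therefore stands at the limit of > 100000 nM in this assay, at which 1 of the 3 values shown sits. Compound 2 gives 64000 nM and compound 3 gives 60000 nM, and these two numbers lie within the usual scatter of each other.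

The next compound is compound 4 `O=[N+]([O-])c1cccc(/N=N/N2CCCC2)c1`, which differs from compound 1 by nitro in place of chloro on an aromatic carbon, meta to a group of 7 heavy atoms: nitro in place of chloro on an aromatic carbon. Within the data shown here, no pair of measured compounds shows this exchange, so the size of the step has no direct support. Compound 3, at 60000 nM, shows that a measurable number is possible for a close relative of compound 1. A modest step toward lower values is expected, though the reading could again be only a limit. The estimated change is an at least 1.4-fold lower number from compound 1 to compound 4 (0.15 log units; that floor lies within the scatter). Compound 4 is expected at 70000 nM, with an estimated range of 30000 nM to 100000 nM.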

Compound 4, half-maximal cytotoxic concentration: > 100000 nM
Compound 4: no number, only a limit; the forecaster's own chance of this, stated with the estimate: 35%; middle value at least 1.4-fold (0.15 log units) from the limit.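

In this assay compound 4 gives > 100000 nM, which is a limit and not a number. Compound 1 also stands at a limit, so no step can be read for nitro in place of chloro: the limit of > 100000 nM in this assay, at which 2 of the 4 values shown sit.

The compounds shown leave open whether this exchange changes tolerance at all, and by how much.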